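This account rests on a few compounds, and the source may have more. Where it says the series, first, only, none or still open, it means among the compounds named here.

Compound 3 `CC1(C)Cc2c(sc(NC(=O)C3CCNC3=O)c2C(N)=O)C(C)(C)O1` gives 101 nM in an assay on cells for positive allosteric modulation of Cystic fibrosis transmembrane conductance regulator variant F508del (Homo sapiens), with stated times of 10 min and 7 s, in the presence of a further agent that is not named here; on this read-out lower numbers stand for an effect already at smaller amounts and higher numbers for an effect only at larger amounts of compound. Its gap to compound 1 `CC1(C)Cc2c(sc(NC(=O)c3cccnc3O)c2C(N)=O)C(C)(C)O1`, which gives 190 nM, is within the scatter, while compound 2 `CC1(C)Cc2c(sc(NC(=O)c3nnc[nH]3)c2C(N)=O)C(C)(C)O1`, which gives 467 nM, lies clearly beyond it, so compound 3 stands at the favourable end of the three numbers shown. Compound 4 `CC1(C)Cc2c(sc(NC(=O)C(C)(C)CO)c2C(N)=O)C(C)(C)O1` differs from compound 3 by 1-(hydroxymethyl)-1-methylethyl in place of 2-oxopyrrolidin-3-yl on a carbonyl carbon. Among the measured compounds shown here, no measured step covers this exact exchange; the nearest are the other swaps on the same carbonyl carbon, a 1.9-fold lower number from compound 1 to compound 3 (0.27 log units; within the scatter), a 4.6-fold lower number from compound 2 to compound 3 (0.66 log units; beyond the scatter) and a 2.5-fold higher number from compound 1 to compound 2 (0.39 log units; beyond the scatter), which range from within the scatter to modest. A step of similar size in this assay, toward a higher number, is therefore expected, a 2.5-fold higher number from compound 3 to compound 4 (0.39 log units; beyond the scatter). Compound 4 is estimated at 250 nM, between 80 nM and 800 nM.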

Compound 4, half-maximal effective concentration: 75 nM
For compound 4 the middle estimate is 3.3-fold (0.52 log units) above the measured one; measured number outside the range, below it.
By their numbers in this assay, from the lowest: compounds 4, 3 and 1 (each within the scatter of the next, the first and the last beyond it); then compound 2.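

On this carbonyl carbon the open chain 1-(hydroxymethyl)-1-methylethyl serves as well in this assay as the 2-oxopyrrolidin-3-yl ring it replaces (a 1.3-fold lower number from compound 3 to compound 4 (0.13 log units; within the scatter)), so among these compounds a ring is not required at this position. Unlike that ring, whose gap to the 2-hydroxypyridin-3-yl group stays within the scatter, the chain separates from both aromatic groups (a 2.5-fold lower number from compound 1 to compound 4 (0.40 log units; beyond the scatter); a 6.2-fold lower number from compound 2 to compound 4 (0.79 log units; beyond the scatter)). Nothing given here accounts for these differences. The compounds shown leave open whether the chain's hydroxyl matters, as a plain tert-butyl group would test, and whether an amine or a carboxylic acid in its place would give a similar number.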